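The compounds below may be only part of what the source reports. "The series", "measured", "known", "first", "only" and "open" are said of these compounds alone.

Series notes, shared core with a thioacetamide link to an aniline bearing one substituent.

Compound 1 is `CCOC(=O)c1cccc(NC(=O)CSc2nc3cccnc3[nH]2)c1` and compound 2 is `CN(C)c1ccc(NC(=O)CSc2nc3cccnc3[nH]2)cc1`. In an assay on isolated protein for inhibition of Ectonucleotide pyrophosphatase/phosphodiesterase family member 1 (Homo sapiens), tested at 10 uM (a higher number here means more inhibition at the concentration tested (going by the name of the read-out), a lower number less inhibition), compound 1 gives 15%, and in this assay compound 2 gives 23%. Compound 2 stands at the top of the two numbers only on paper: the gap to compound 1 is within the usual scatter of this assay, so the two compounds cannot be separated from each other on the present data.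

Compound 3 is `O=C(CSc1nc2cccnc2[nH]1)Nc1ccc(Cl)cc1`. Its difference from compound 2 is chloro in place of dimethylamino on an aromatic carbon. Among the compounds with values here, no measured pair shows what this kind of exchange does here, so the expectation rests on compound 1 and compound 2 alone, whose values sit close together. The step expected from compound 2 to compound 3 in this assay is a number 5 percentage points lower from compound 2 to compound 3 (within the scatter), which is no step beyond the scatter in either direction. For compound 3 the value estimated in this assay is 18%, with a range from 5% to 35%.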

Compound 3, a percentage reported as inhibition, at one concentration (the size of the read-out at that concentration, not a potency): 17%
Estimate against measurement, compound 3: 1 percentage points above; measured number inside the range.
By their numbers in this assay, from the lowest: compounds 1, 3 and 2 (each within the scatter of the next).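

In this assay, within the data shown here, the exchange of dimethylamino for chloro on an aromatic carbon, para to a large group, gives a number 6 percentage points lower from compound 2 to compound 3 (within the scatter) and is the first one-place step. At this position, then, a group with a hydrogen-bond acceptor and one without give numbers that cannot be separated, so this pair shows no sign that the choice between these two substituents matters. No measurement on these compounds offers an explanation of the step.

Still open, going by these compounds, is whether any substituent at this position can move the number beyond the scatter, since the three compounds so far stay within it of one another. A carboxylic acid or a primary amine at the same place would test this, as would a longer chain in place of the thioacetamide link.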